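Biphenyl replaces methoxyphenyl on the carbonyl: compound 4

A few compounds are considered here, and "the series" means these few. Any claim that something is new, unique, unknown or untested is made for them only; others in the source may bear on it.

Compound 3 `COc1ccc(/C=C/c2cc(OC)cc(OC)c2/C=C/C(=O)c2cccc(OC)c2)cc1` gives 6.1 ug/mL in a functional assay on A549 cells (Homo sapiens) for antiproliferative activity, read by MTT assay, with a stated time of 48 h; on this read-out higher numbers stand for weaker inhibition and lower numbers for stronger inhibition. It stands second highest of the three numbers, nearest compound 1 `CCOc1ccc(C(=O)/C=C/c2c(/C=C/c3ccc(OC)cc3)cc(OC)cc2OC)cc1` with 7.5 ug/mL, and furthest from compound 2 `COc1ccc(/C=C/c2cc(OC)cc(OC)c2/C=C/C(=O)c2ccc(OC)cc2)cc1` with 4.5 ug/mL; both gaps, a 1.2-fold lower number from compound 1 to compound 3 (0.09 log units; within the scatter) and a 1.4-fold higher number from compound 2 to compound 3 (0.13 log units; within the scatter), lie within the scatter. Compound 4 `COc1ccc(/C=C/c2cc(OC)cc(OC)c2/C=C/C(=O)c2ccc(-c3ccccc3)cc2)cc1` differs from compound 3 by 4-phenylphenyl in place of 3-methoxyphenyl on a carbonyl carbon. For the measured compounds named here, the measured steps that touch the same carbonyl-bound aryl group, a 1.4-fold higher number from compound 2 to compound 3 (0.13 log units; within the scatter) and a 1.2-fold lower number from compound 1 to compound 3 (0.09 log units; within the scatter), were small and within the scatter; no measured step covers a change of this kind, so the expectation is set near compound 3 with a wide range. Compound 4 is therefore expected to give 7 ug/mL, between 3 ug/mL and 16 ug/mL, a step of a 1.1-fold higher number from compound 3 to compound 4 (0.06 log units; within the scatter).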

Compound 4, half-maximal inhibitory concentration: 4.6 ug/mL
Beside the measured number, compound 4's estimate is 1.5-fold (0.18 log units) above it; the range from low to high includes it.
By their numbers in this assay, from the lowest: compounds 2, 4, 3 and 1 (each within the scatter of the next).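

In (this assay) the carbonyl carbon takes 4-phenylphenyl, with its two aromatic rings and no hydrogen-bond acceptor, and every step stays within the scatter (a 1.3-fold lower number from compound 3 to compound 4 (0.12 log units; within the scatter)) (a 1.0-fold higher number from compound 2 to compound 4 (0.01 log units; within the scatter)) (a 1.6-fold lower number from compound 1 to compound 4 (0.21 log units; within the scatter)). An oxygen on this aryl group is therefore not required for values in this range in the shared core.

From the compounds shown here alone, whether an amine or a carboxylic acid on this aryl group would move the number beyond the scatter remains open. No evidence on the reason for these small steps is available.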